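A few compounds are considered here, and "the series" means these few. Any claim that something is new, unique, unknown or untested is made for them only; others in the source may bear on it.

Measured so far:
compound 1 `COC(=O)[C@H](CC(C)C)NC(=O)c1cnc2ccccc2c1Cl`: 49.1 uM
compound 2 `COC(=O)[C@H](CO)NC(=O)c1cnc2ccccc2c1Cl`: > 100 uM

In an ADME assay on CCRF-CEM cells (Homo sapiens) for cytotoxicity (on this read-out lower numbers stand for higher toxicity in this test and higher numbers for lower toxicity in this test), compound 1 gives 49.1 uM. Compound 2 gives > 100 uM, a limit of the assay rather than a number. Compound 2 therefore stands at the limit of > 100 uM in this assay, at which 1 of the 2 values shown sits. For the measured compounds named here, the only measured step, an at least 2.0-fold higher number from compound 1 to compound 2 (0.30 log units; that floor lies within the scatter), concerns the side chain and carries no information on an aromatic substituent. Compound 3 `COC(=O)[C@H](CO)NC(=O)c1cnc2cc(C)ccc2c1Cl` differs from compound 2 by methyl in place of hydrogen on an aromatic carbon. Going by the values given here, no measured step bears on this change, so no shift beyond the scatter is expected, and compound 3 is expected to stay near the limit, a number no higher from compound 2 to compound 3 (the limit leaves the size open). The estimate for compound 3 is 100 uM, in a range from 40 uM to 300 uM.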

Compound 3, half-maximal toxic concentration: 59.6 uM
Compound 3: the middle estimate sits 1.7-fold (0.22 log units) above what was measured, and the stated range covers the measured number.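

Methyl in place of hydrogen on this aromatic carbon, meta to a fused ring and para to a fused ring, gives the first reading on the aromatic part of the series in this assay, with an at least 1.6-fold lower number from compound 2 to compound 3 (0.22 log units; that floor lies within the scatter). Compound 3 gives a number, 59.6 uM, so the methyl compound lies within the measurable range. The true size of the step stays unknown, since compound 2 is held by a limit: the limit of > 100 uM in this assay, at which 1 of the 3 values shown sits.

As far as these compounds go, whether an amine or a longer chain on this carbon would give a step beyond the scatter stays open. Also open, from the compounds shown here alone, is whether methyl gives a similar result on the side chain of compound 1.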